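The compounds below may be only part of what the source reports. "The series", "measured", "known", "first", "only" and "open" are said of these compounds alone.

Compound 1 `CCCC(=O)N(C)c1ccc(C(O)(C(F)(F)F)C(F)(F)F)cc1` gives in an ADME assay on Li23 cells (Homo sapiens) for cytotoxicity, read by WST assay (on this read-out lower numbers stand for higher toxicity in this test and higher numbers for lower toxicity in this test), only a limit, > 100000 nM (the limit of > 100000 nM in this assay, at which 1 of the 2 values shown sits). Within the data shown here, compound 2 `CCCCC(=O)N(C)c1ccc(C(O)(C(F)(F)F)C(F)(F)F)cc1` gives 26000 nM, the only actual number among the two values shown. Between them lies an at least 3.8-fold lower number from compound 1 to compound 2 (0.58 log units; beyond the scatter). Compound 3 `CN(C(=O)c1cccs1)c1ccc(C(O)(C(F)(F)F)C(F)(F)F)cc1` differs from compound 2 by thiophen-2-yl in place of butyl on a carbonyl carbon. Among the measured compounds shown here, no measured step covers this kind of exchange; the single known step concerns a chain extension and does not bear on it. The expected step is a 1.5-fold higher number from compound 2 to compound 3 (0.19 log units; within the scatter), close to the scatter and uncertain in direction. Compound 3 is therefore estimated at 40000 nM, within 10000 nM to 150000 nM.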

Compound 3, half-maximal cytotoxic concentration: 33000 nM
Compound 3: middle estimate off by 1.2-fold (0.08 log units), on the high side; measured number inside the range.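

In this assay, thiophen-2-yl in place of butyl on the carbonyl carbon gives a 1.3-fold higher number from compound 2 to compound 3 (0.10 log units; within the scatter), so a five-membered aromatic ring and a saturated chain cannot be told apart here. Set against propyl, the same ring gives an at least 3.0-fold lower number from compound 1 to compound 3 (0.48 log units; beyond the scatter), so the lower number seen earlier with butyl is not confined to chain extension. Compound 1 gives only a limit, not a number: the limit of > 100000 nM in this assay, at which 1 of the 3 values shown sits.

The compounds shown leave open whether a phenyl ring, a longer chain or an amine on this carbonyl carbon would move the number beyond the scatter.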